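Flexible ether ester on the dihydropyridine core

The source may hold more compounds than are shown below. What is called first, only, known or untested is meant among the compounds shown, and "the series" means these compounds.

Measured so far:
compound 1, `COC(=O)C1=C(C)NC(C)=C(C(=O)OC2C=CCCC2)C1c1cccc([N+](=O)[O-])c1`: 10 nM
compound 2, `COC(=O)C1=C(C)NC(C)=C(C(=O)OC2Cc3ccccc3C2)C1c1cccc([N+](=O)[O-])c1`: 72 nM

Compound 2 gives the highest of the two numbers in a functional assay on HEK293 cells for antagonist activity at Voltage-dependent L-type calcium channel subunit alpha-1C (Oryctolagus cuniculus), read by FLIPR; on this read-out lower numbers stand for stronger inhibition and higher numbers for weaker inhibition; its nearest neighbour is compound 1, and the step of a 7.2-fold higher number from compound 1 to compound 2 (0.86 log units; beyond the scatter) lies beyond the scatter. Compound 3, `COC(=O)C1=C(C)NC(C)=C(C(=O)OCCOCc2ccccc2)C1c1cccc([N+](=O)[O-])c1`, has not yet been measured. It differs from compound 2 in one place: 2-(benzyloxy)ethyl in place of 2,3-dihydro-1H-inden-2-yl on an oxygen next to a carbonyl group. Going by the values given here, the only step that bears on this change is the one at the same ester oxygen, a 7.2-fold higher number from compound 1 to compound 2 (0.86 log units; beyond the scatter), which shows that exchanging the group on this oxygen can shift the number by a modest amount. Compound 3 carries a flexible chain rather than a ring there, so an intermediate outcome is expected, and compound 3 is estimated to sit between the two measured values at about 25 nM, within a range of 6 nM to 100 nM. The expected step from compound 2 to compound 3 is therefore a 2.9-fold lower number from compound 2 to compound 3 (0.46 log units; beyond the scatter) in this assay.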

Compound 3, half-maximal inhibitory concentration: 9 nM
Beside the measured number, compound 3's estimate is 2.8-fold (0.44 log units) above it, within the range that was stated.
By their numbers in this assay, from the lowest: compounds 3 and 1 (each within the scatter of the next); then compound 2.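

Exchanging 2,3-dihydro-1H-inden-2-yl for 2-(benzyloxy)ethyl on an oxygen next to a carbonyl group gives an 8.0-fold lower number from compound 2 to compound 3 (0.90 log units; beyond the scatter) in this assay, so a change at this oxygen can also lower the number, and by a step of similar size to the earlier rise. The open chain of compound 3 keeps the six-membered aromatic ring but not the five-membered ring of the group it replaces, and it stands level with the cyclohex-2-en-1-yl ester, with a 1.1-fold lower number from compound 1 to compound 3 (0.05 log units; within the scatter), so among these compounds a ring bonded directly to this oxygen is not needed for a low number. Nothing available accounts for either step.

Open, going by these compounds, is whether an all-carbon phenylalkyl chain, without the ether oxygen, would match compound 3. Also open, on these data alone, is how a longer chain or one ending in an amine would fare at this oxygen.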